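A few compounds are considered here, and "the series" means these few. Any claim that something is new, unique, unknown or untested is made for them only; others in the source may bear on it.

Working notes on the series. Compound 1 `CCOC(=O)Nc1nccc(-c2ccncc2)n1` and compound 2 `NC(=O)Nc1nccc(-c2ccncc2)n1` share one core; compound 3 `CCOC(=O)Nc1ncc(-c2ccccc2)c(C(C)(C)C)n1` and compound 4 `CC(C)(C)c1nc(NC(N)=O)ncc1-c1ccccc1` share another. The difference between the two cores is not broken down here.

In a functional assay on the whole organism for inhibition, with Rattus norvegicus as the target, with stated times of 1 h and 3.5 h, at a dose of 100 mg/kg by the oral route (on this read-out lower numbers stand for less inhibition and higher numbers for more inhibition at the one dose given (going by the name of the read-out)), compound 1 gives 31%. Compound 2 differs from compound 1 by amino in place of ethoxy on a carbonyl carbon, and in this assay compound 2 gives 12%. That change made a step of a number 19 percentage points lower from compound 1 to compound 2 (beyond the scatter). Compound 3, in this assay, gives 24%; against compound 1 this lies within the scatter, against compound 2 beyond it.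

Compound 4 differs from compound 3 by amino in place of ethoxy on a carbonyl carbon, the same change as that from compound 1 to compound 2, now made on the other core; the surroundings of the carbonyl carbon read the same in both cases. Among the measured compounds shown here, only one measured instance of this change exists, and it sits on a core that is not the core of compound 3, so how far the step carries over is open. For the measured compounds named here, the step in this assay is estimated at a number 17 percentage points lower from compound 3 to compound 4 (beyond the scatter), resting on the single step of a number 19 percentage points lower from compound 1 to compound 2 (beyond the scatter) and widened for the lack of a second example. For compound 4 in this assay the estimate is 7%, expected to lie between -6% and 22%.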

Compound 4, a percentage reported as inhibition, in the whole organism at one dose (the size of the read-out at that dose, not a potency): 14%
For compound 4 the middle estimate is 7 percentage points below the measured one; low and high end bracket the measured number.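

In this assay, amino in place of ethoxy on a carbonyl carbon, which turns the (ethoxycarbonyl)amino group into a ureido group, now gives a number 10 percentage points lower from compound 3 to compound 4 (within the scatter). Among the compounds shown here, the change therefore carries over to the second core without a measurable difference in the size of its step: the same change on two cores in this assay, a number 19 percentage points lower (beyond the scatter) from compound 1 to compound 2 and a number 10 percentage points lower (within the scatter) from compound 3 to compound 4, 9 percentage points apart, within the scatter of two such steps This does not establish a fixed step for the change: only two cores are compared, the step on the core of compound 3 does not itself clear the scatter, and the read-out gives the size of the inhibition at a single dose, not a potency, so a real difference between the cores of moderate size could pass unseen.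

The compounds shown leave open whether the same step would appear on a third core, and whether it would hold at other doses of the read-out. They also leave open what other groups on the same carbonyl carbon would give, such as methoxy, a longer alkoxy chain such as butoxy, or a dimethylamino group, since ethoxy and amino are the only two shown there.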